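The compounds below may be only part of what the source reports. "The series", "measured", "known", "first", "only" and "open" are said of these compounds alone.

In a functional assay on NCI-H460 cells (Homo sapiens) for cytotoxicity, read by sulforhodamine B assay (a higher number here means a weaker inhibitor of growth, a lower number a stronger inhibitor of growth), compound 1 `CC1=CC[C@@H]([C@@](C)(O)CCCC(C)(C)NC(=S)N/N=C\c2ccc(C)cc2)CC1` gives 10100 nM and compound 2 `CC1=CC[C@@H]([C@@](C)(O)CCCC(C)(C)NC(=S)N/N=C\c2ccccc2[N+](=O)[O-])CC1` gives 20600 nM. Compound 1 therefore holds the lower of the two numbers and is the stronger inhibitor of growth in this pair. Compound 3 `CC1=CC[C@@H]([C@@](C)(O)CCCC(C)(C)NC(=S)N/N=C(/C)c2ccccc2)CC1` has not yet been measured. It keeps the core of compound 1 and differs only on an amide-type nitrogen whose other neighbour is a thiocarbonyl carbon: a group of 9 heavy atoms (8 carbon, 1 nitrogen; one six-membered aromatic ring of carbon only) in place of a group of 9 heavy atoms (8 carbon, 1 nitrogen; one six-membered aromatic ring of carbon only), on an amide-type nitrogen. The two compounds have the same atoms, joined differently.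

For the measured compounds named here, only one measured step bears on this change, and only in part. Exchanging one substituted phenyl group for another gave a 2.0-fold higher number from compound 1 to compound 2 (0.31 log units; beyond the scatter), a modest change. With that single step as a guide, a shift no larger than this is expected in this assay, and the data give no firm direction. The estimated change is a 1.2-fold higher number from compound 1 to compound 3 (0.07 log units; within the scatter). For compound 3 the expected value is 12000 nM, with an estimated range from 5500 nM to 26000 nM.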

Compound 3, concentration for 50% growth inhibition: 12600 nM
For compound 3 the middle estimate is 1.1-fold (0.02 log units) below the measured one; the measured number falls inside the stated range.
By their numbers in this assay, from the lowest: compounds 1, 3 and 2 (each within the scatter of the next, the first and the last beyond it).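

Compound 1 and compound 3 hold the same atoms joined differently, and in this assay this rearrangement of the group on the amide-type nitrogen stays within the scatter (a 1.2-fold higher number from compound 1 to compound 3 (0.10 log units; within the scatter)), so the assay cannot tell the two compounds apart. The earlier step showed only that exchanging 4-methylphenyl for 2-nitrophenyl could carry the number just beyond the scatter, whereas this step shows that the group can be rebuilt, keeping its heavy-atom count and its aromatic ring, with no readable difference in growth inhibition. No measured evidence is available to account for this result.

Going by these compounds, what a pyridine ring or a cyclohexyl group would do in place of the aromatic ring of carbon only remains open, and with it the question of whether an aromatic ring is needed in this group at all. On these data alone, the three compounds also share the rest of their structure and are compared in one cell line, so the role of the thiocarbonyl, or of a carbonyl in its place, remains open too.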